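Removing One Chloro from a Dichloro Hydrazone Analogue

A few compounds are considered here, and "the series" means these few. Any claim that something is new, unique, unknown or untested is made for them only; others in the source may bear on it.

Compound 1 `COc1ccc(/C=N/NC(=O)c2ccc(C)cc2O)cc1`: 723000 nM
Compound 2 `Cc1ccc(C(=O)N/N=C/c2ccccc2)c(O)c1`: 578000 nM
Compound 3 `Cc1ccc(C(=O)N/N=C/c2ccc(Cl)cc2Cl)c(O)c1`: 291000 nM

In an ADME assay on cells (Mus musculus, strain BALB/C) for cytotoxicity, read by MTT assay, with a stated time of 24 h (on this read-out higher numbers stand for lower toxicity in this test and lower numbers for higher toxicity in this test), compound 3 stands at the low end of the three numbers: its gap to compound 2 is within the scatter, while its gap to compound 1 lies beyond it. Compound 4 `Cc1ccc(C(=O)N/N=C/c2ccc(Cl)cc2)c(O)c1` differs from compound 3 by hydrogen in place of chloro on an aromatic carbon. Among the compounds with values here, the only single-point step measured so far, a 1.3-fold lower number from compound 1 to compound 2 (0.10 log units; within the scatter), concerns a methoxy rather than a chloro and so does not bear directly on this change; no measured step removes a chloro. Compound 2, which carries no chloro, gives 578000 nM, and compound 3 with two gives 291000 nM, so compound 4 is expected to fall between them. Compound 4 is therefore estimated at 400000 nM (range 200000 nM to 800000 nM), a step of a 1.4-fold higher number from compound 3 to compound 4 (0.14 log units; within the scatter) that is expected to stay within the scatter.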

Compound 4, half-maximal cytotoxic concentration: 116000 nM
Compound 4: the middle estimate sits 3.4-fold (0.54 log units) above what was measured, outside the stated range (below it).
By their numbers in this assay, from the lowest: compound 4; then compounds 3, 2 and 1 (each within the scatter of the next, the first and the last beyond it).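

In this assay taking away the chloro ortho to a large group gives a 2.5-fold lower number from compound 3 to compound 4 (0.40 log units; beyond the scatter) and so leaves compound 4 lowest of the four, not between compound 2 and compound 3. Chloro in place of hydrogen gives a 5.0-fold lower number from compound 2 to compound 4 (0.70 log units; beyond the scatter) while chloro in place of methoxy gives a 6.2-fold lower number from compound 1 to compound 4 (0.79 log units; beyond the scatter) and, with compound 3 higher again, the effect of the two chloro groups is not additive. Nothing measured here explains this reversal.

On these data alone, it remains open whether a fluoro, a methyl or an amine ortho to a large group would also raise the number. Whether a lone chloro at that position would behave like the chloro in compound 4 is open as well.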